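Aryl versus lactam substituent on the thiazole-linked series

The compounds below may be only part of what the source reports. "The series", "measured", "known", "first", "only" and "open" are said of these compounds alone.

Measured so far:
compound 1 `COc1cc(OCc2csc(-c3ccc(C(C)(C)O)cc3)n2)c2cc(-c3cn4nc(OC)sc4n3)oc2c1` — 2.4 nM
compound 2 `COc1cc(OCc2csc(N3CCOCC3=O)n2)c2cc(-c3cn4nc(OC)sc4n3)oc2c1` — 1.7 nM

Two compounds share the core and differ only in the group on the thiazole carbon. In a functional assay on HEK293 cells for antagonist activity at proteinase-activated receptor 4 (Homo sapiens), read by FLIPR and calcium flux, with a stated time of 30 min (a higher number here means a weaker inhibitor, a lower number a stronger inhibitor), compound 1 gives 2.4 nM and compound 2 gives 1.7 nM. For the measured compounds named here, the one measured step, a 1.4-fold lower number from compound 1 to compound 2 (0.15 log units; within the scatter), leaves the two numbers within the scatter of each other, so compound 2 stands level with compound 1 rather than apart from it.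

Compound 3 `COc1cc(OCc2csc(-c3ccc(OC)nc3)n2)c2cc(-c3cn4nc(OC)sc4n3)oc2c1` is not yet measured. The change from compound 2 is 6-methoxypyridin-3-yl in place of 3-oxomorpholin-4-yl on an aromatic carbon. Going by the values given here, the only step that bears on it, a 1.4-fold lower number from compound 1 to compound 2 (0.15 log units; within the scatter), shows that exchanging an aromatic group for the lactam at this position moved the number hardly at all. Compound 3 returns an aromatic group to the same place, so no step beyond the scatter is expected in this assay. The estimate for compound 3 is 2.5 nM, with a range of 1 nM to 6 nM; the expected step is a 1.5-fold higher number from compound 2 to compound 3 (0.17 log units; within the scatter).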

Compound 3, half-maximal inhibitory concentration: 0.8 nM
Beside the measured number, compound 3's estimate is 3.1-fold (0.49 log units) above it; the whole stated range lies above it.
By their numbers in this assay, from the lowest: compound 3; then compounds 2 and 1 (each within the scatter of the next).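

In this assay, for the compounds shown here, this position responds to the group it carries: 6-methoxypyridin-3-yl in place of 3-oxomorpholin-4-yl gives a 2.1-fold lower number from compound 2 to compound 3 (0.33 log units; beyond the scatter) and 6-methoxypyridin-3-yl in place of 4-(1-hydroxy-1-methylethyl)phenyl gives a 3.0-fold lower number from compound 1 to compound 3 (0.48 log units; beyond the scatter) as the only steps beyond the scatter, both modest, and they leave compound 3 the strongest inhibitor of the three. A six-membered aromatic ring alone does not set the number, since compound 1 also carries one yet stands within the scatter of compound 2, which has the non-aromatic 3-oxomorpholin-4-yl. No measurement on hand accounts for the difference between these groups.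

The compounds shown leave open whether the methoxy group or the ring nitrogen of 6-methoxypyridin-3-yl underlies the step. Also open, from the compounds shown here alone, is how an amine or a carboxylic acid in place of that methoxy group would read in this assay against compound 3.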